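From 1-benzofuran-2-yl to ethynyl on the shared core

The compounds below may be only part of what the source reports. "The series", "measured", "known", "first", "only" and "open" are said of these compounds alone.

In a functional assay on HCT-116 cells (Homo sapiens), read by MTT assay, with a stated time of 72 h (on this read-out higher numbers stand for weaker inhibition and lower numbers for stronger inhibition), compound 2 (`Cc1ncnc2c1c(-c1cc3ccccc3o1)cn2[C@@H]1O[C@H](CO)[C@@H](O)[C@H]1O`) gives > 20000 nM as a limit and not a number. Compound 3 (`C#Cc1cn([C@@H]2O[C@H](CO)[C@@H](O)[C@H]2O)c2ncnc(C)c12`) carries ethynyl in place of 1-benzofuran-2-yl on an aromatic carbon. Within the data shown here, no measured step covers this change. A large move towards stronger inhibition in this assay is expected, because compound 1 (`C#Cc1cn([C@@H]2O[C@H](CO)[C@@H](O)[C@H]2O)c2ncnc(N(C)C)c12`), which also bears ethynyl, gives 180 nM in that assay. The expected change is an at least 66-fold lower number from compound 2 to compound 3 (1.82 log units; beyond the scatter) as estimated here. The estimated value for compound 3 is 300 nM (expected range 40 nM to 3000 nM).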

Compound 3, half-maximal inhibitory concentration: > 20000 nM
Compound 3 ended at the assay's limit; the forecaster's own chance of this, stated with the estimate: 10%; at least 66-fold (1.82 log units) between middle value and limit.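

In this assay, ethynyl on the shared core is not enough for a readable value, since compound 3 also ended at a limit of the assay. The step between compound 2 and compound 3 therefore cannot be read, and ethynyl and 1-benzofuran-2-yl cannot be ranked at this position: the limit of > 20000 nM in this assay, at which 2 of the 3 values shown sit. The second point of change carries the difference, with methyl in place of dimethylamino on an aromatic carbon giving an at least 110-fold higher number from compound 1 to compound 3 (2.04 log units; beyond the scatter).

Open, going by these compounds, is whether a smaller amine, such as methylamino or a free amino group, would hold the value of compound 1. Also open, on these data alone, is whether 1-benzofuran-2-yl paired with dimethylamino would give a readable value.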